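Swapping 3-aminopropyl for 2-hydroxyethyl on a weak cytotoxic compound

The compounds below may be only part of what the source reports. "The series", "measured", "known", "first", "only" and "open" are said of these compounds alone.

Measured in a functional assay on HCT-116 cells (Homo sapiens) for cytotoxicity, read by MTT assay, with a stated time of 72 h; on this read-out higher numbers stand for weaker inhibition and lower numbers for stronger inhibition:
- compound 1 `N[C@H]1CC[C@H](Nc2c(C(=O)NCc3ccc(F)cc3)nc(N3CCCCS3(=O)=O)c3cccnc23)CC1`: > 10000 nM (a limit)
- compound 2 `NCCCNc1c(C(=O)NCc2ccc(F)cc2)nc(Br)c2cccnc12`: 18000 nM
- compound 3 `CC(C)(C)OC(=O)N1CCN(c2c(C(=O)NCc3ccc(F)cc3)nc(Br)c3cccnc23)CC1`: > 10000 nM (a limit)

Among these three, compound 2 gives the only actual number in this assay, at 18000 nM. Compound 1 and compound 3 offer no number, only a limit: the limit of > 10000 nM in this assay, at which 2 of the 3 values shown sit.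

Compound 4 `O=C(NCc1ccc(F)cc1)c1nc(Br)c2cccnc2c1NCCO` shares its core with compound 2 and differs in one chain: hydroxy in place of aminomethyl on a saturated chain carbon, two bonds along the chain from a nitrogen on an aromatic ring. In words, hydroxy stands in place of aminomethyl on a saturated chain carbon, two bonds along the chain from a nitrogen on an aromatic ring, so that 3-aminopropyl becomes 2-hydroxyethyl.

No measured step between any of these compounds is available to serve as a guide. The expectation therefore rests on compound 2 at 18000 nM and on the structural change alone. The estimated step of a 1.1-fold higher number from compound 2 to compound 4 (0.05 log units; within the scatter) is expected to stay within the usual scatter, with no clear direction. For compound 4 the estimated value is 20000 nM, with an expected range from 8000 nM to 50000 nM.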

Compound 4, half-maximal inhibitory concentration: > 20000 nM
Compound 4 was reported as a limit (the forecaster's own chance of this, stated with the estimate: 55%); the middle value sits exactly at the limit.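

Among the compounds shown, this is the only comparison that differs in one place, and it gives, in this assay, an at least 1.1-fold higher number from compound 2 to compound 4 (0.04 log units; that floor lies within the scatter). Compound 4 is reported only as a limit: the limit of > 20000 nM in this assay, at which 1 of the 4 values shown sits. From the compounds shown here alone, the floor of this step therefore lies within the scatter and its true size is unknown, but hydroxy in place of aminomethyl on this chain gives no sign of stronger inhibition, so 2-hydroxyethyl offers no measurable gain over 3-aminopropyl here.

The compounds shown leave open how a 2-aminoethyl chain, a longer chain ending in an amine, or a chain ending in a carboxylic acid would read at this position. They also leave open how far the true value of compound 4 lies from its limit.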